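The compounds below may be only part of what the source reports. "The series", "measured", "known", "first", "only" and "open" are said of these compounds alone.

Compound 1 `O=C1Nc2ccc(Br)cc2/C1=N/NC(=S)N1CCN(c2ccccc2)CC1`: 20500 nM
Compound 2 `O=C1Nc2cc(Cl)ccc2/C1=N/NC(=S)N1CCN(c2ccccc2)CC1`: 23000 nM
Compound 3 `O=C1Nc2ccc(Cl)cc2/C1=N/NC(=S)N1CCN(c2ccccc2Cl)CC1`: 11700 nM

These three compounds were tested in a functional assay on MCF7 cells (Homo sapiens) for inhibition, read by MTT assay, with a stated time of 72 h; a lower number here means a stronger inhibitor, a higher number a weaker inhibitor. Compound 3 gives 11700 nM, the lowest of the three numbers. Its gap to compound 1, which gives 20500 nM, and its gap to compound 2, which gives 23000 nM, both lie within the scatter, so none of the three can be set apart from the others on these numbers alone.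

Compound 4 `O=C1Nc2ccc(Cl)cc2/C1=N/NC(=S)N1CCN(c2ccccc2[N+](=O)[O-])CC1` has not yet been measured in this assay. It differs from compound 3 in one place: nitro in place of chloro on an aromatic carbon. Among the compounds with values here, no step between measured compounds matches this change, so there is no direct guide to its effect. The three measured values sit close together, which gives no reason to expect a large step here. The step from compound 3 to compound 4 is expected to be a 1.0-fold higher number from compound 3 to compound 4 (0.01 log units; within the scatter), a change not beyond the scatter. Compound 4 is estimated to give 12000 nM, with a range from 4000 nM to 36000 nM.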

Compound 4, half-maximal inhibitory concentration: 7490 nM
Estimate against measurement, compound 4: 1.6-fold (0.20 log units) above; the range from low to high includes it.
By their numbers in this assay, from the lowest: compounds 4, 3, 1 and 2 (each within the scatter of the next, the first and the last beyond it).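

In this assay, within the data shown here, the exchange of 2-chlorophenyl for 2-nitrophenyl gives a 1.6-fold lower number from compound 3 to compound 4 (0.19 log units; within the scatter) and this is the first step in the set that can be read at a single place. This aromatic carbon, ortho to a large group, thus carries nitro as well as chloro, and the two hydrogen-bond acceptors that enter with nitro leave compound 4 within the scatter of compound 3. No measurement given here bears on why the two groups read alike.

The compounds shown leave open whether this position responds at all to a group of another kind, such as an amine, a carboxylic acid or plain hydrogen. Going by these compounds, whether the same exchange would give a similar step elsewhere on that aromatic ring also remains open.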